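The compounds below may be only part of what the source reports. "The series", "measured", "known", "first", "only" and "open" are said of these compounds alone.

For the measured compounds named here, compound 3 `O=C(Nn1c(-c2cccc([N+](=O)[O-])c2)nc2c(-c3cccc(Cl)c3)n[nH]c2c1=O)c1ccccc1` gives 93.8% in a functional assay on DU-145 cells (Homo sapiens) for cytotoxicity, read by sulforhodamine B assay, with a stated time of 2 days, tested at 100 uM (on this read-out higher numbers stand for more inhibition at the one concentration tested (going by the name of the read-out) and lower numbers for less inhibition), the highest of the three numbers measured so far; compound 2 `CCCc1n[nH]c2c(=O)n(NC(=O)c3ccccc3)c(-c3cccc([N+](=O)[O-])c3)nc12` gives 27.8% and compound 1 `O=C(Nn1c(-c2cccc([N+](=O)[O-])c2)nc2c(-c3ccc(F)cc3)n[nH]c2c1=O)c1cccnc1` gives 24.9%. Going by the values given here, the only measured step at the same aromatic carbon is a number 66 percentage points higher from compound 2 to compound 3 (beyond the scatter), which shows how much the group there can matter. Compound 4 `O=C(Nn1c(-c2cccc([N+](=O)[O-])c2)nc2c(-c3ccc(F)cc3)n[nH]c2c1=O)c1ccccc1` carries 4-fluorophenyl in place of 3-chlorophenyl on an aromatic carbon. Compound 1 also bears a 4-fluorophenyl but differs from compound 3 in a second place as well, so its low value can only suggest that compound 4 may come out lower than compound 3. A downward step beyond the scatter is therefore expected, a number 48.8 percentage points lower from compound 3 to compound 4 (beyond the scatter), with wide uncertainty. Compound 4 is estimated at 45%, in a range from 15% to 85%.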

Compound 4, a percentage reported as inhibition, at one concentration (the size of the read-out at that concentration, not a potency): 90.8%
For compound 4 the middle estimate is 45.8 percentage points below the measured one, outside the stated range (above it).
By their numbers in this assay, from the lowest: compounds 1 and 2 (each within the scatter of the next); then compounds 4 and 3 (each within the scatter of the next).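

In this assay 4-fluorophenyl and 3-chlorophenyl are not told apart at this aromatic carbon, with a number 3 percentage points lower from compound 3 to compound 4 (within the scatter) and with a number 63 percentage points higher from compound 2 to compound 4 (beyond the scatter) in the comparison with propyl, so the high number is not tied to one particular aryl group. The low number of compound 1 does not go with 4-fluorophenyl: phenyl in place of pyridin-3-yl on a carbonyl carbon brings a number 65.9 percentage points higher from compound 1 to compound 4 (beyond the scatter) and marks the carbonyl side as a second place where the group matters. No measured property explains either change. Open, on these data alone, is whether an amine or a carboxylic acid on the aryl ring, or a longer chain in place of propyl, would hold the number at this carbon.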